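Replacing 4-bromophenyl with cyclopropyl: notes on compound 4

The source may report more compounds than this note shows. Statements on the series, on what has been measured and on what is new or still open speak of the compounds shown alone.

Within the data shown here, in a functional assay on HepG2 cells (Homo sapiens) for antiproliferative activity, read by MTT assay, with a stated time of 72 h (a lower number here means a stronger inhibitor, a higher number a weaker inhibitor), compound 2 `O=C1O[C@H]([C@@H](O)Cn2cc(-c3ccc(Br)cc3)nn2)C(OCc2ccccc2)=C1OCc1ccccc1` gives 5070 nM, the only true number among the three measured compounds. Compound 1 `O=C1O/C(=C\Cn2cc(-c3ccc(Br)cc3)nn2)C(OCc2ccccc2)=C1OCc1ccccc1` reads > 100000 nM, which is a limit and not a number. Compound 3 `O=C1O/C(=C\Cn2cc(-c3cc(C(F)(F)F)cc(C(F)(F)F)c3)nn2)C(OCc2ccccc2)=C1OCc1ccccc1` reads > 100000 nM, again a limit. The series therefore offers a single numerical reference point.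

Compound 4 `O=C1O[C@H]([C@@H](O)Cn2cc(C3CC3)nn2)C(OCc2ccccc2)=C1OCc1ccccc1` keeps the rest of compound 2 and carries cyclopropyl in place of 4-bromophenyl on an aromatic carbon of a five-membered aromatic ring with 3 nitrogen: cyclopropyl in place of 4-bromophenyl on an aromatic carbon. Among the measured compounds shown here, no two measured compounds differ in one place, so the data give no direct measure of this change. With compound 2 at 5070 nM as the starting point, a moderate loss of inhibition is expected, though with wide uncertainty. The expected change in this assay is a 3.0-fold higher number from compound 2 to compound 4 (0.47 log units; beyond the scatter), towards weaker inhibition. For compound 4 the estimated value is 15000 nM, with an expected range from 3500 nM to 70000 nM.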

Compound 4, half-maximal inhibitory concentration: 38100 nM
Beside the measured number, compound 4's estimate is 2.5-fold (0.40 log units) below it; the range from low to high includes it.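

Working note on the aromatic carbon of the five-membered aromatic ring with 3 nitrogen: this is the first one-place step in the series, and it shows that the read-out responds to the group at this carbon. In this assay, cyclopropyl in place of 4-bromophenyl gives a 7.5-fold higher number from compound 2 to compound 4 (0.88 log units; beyond the scatter). The 4-bromophenyl group is therefore not needed for a true number, since compound 4 still gives one, whereas compound 1 and compound 3 each read only as a limit and not a number: the limit of > 100000 nM in this assay, at which 2 of the 4 values shown sit.

The pair does not separate the loss of the bromine from the loss of the six-membered aromatic ring, and an unsubstituted phenyl at this carbon would address that. On these data alone, how a longer alkyl chain or an amine at this carbon would read remains open.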